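A few compounds are considered here, and "the series" means these few. Any claim that something is new, unique, unknown or untested is made for them only; others in the source may bear on it.

Working notes on the series, all read in a functional assay on HeLa cells (Homo sapiens) for antiproliferative activity, read by MTT assay, with a stated time of 72 h; on this read-out lower numbers stand for stronger inhibition and higher numbers for weaker inhibition. Within the data shown here, compound 1 `COc1cc(-n2ncnc2-c2ccc(C)cc2)cc(OC)c1OC` gives 250 nM, the only actual number so far. Compound 2 `CCOc1cccc(-c2ncnn2-c2cc(OC)c(OC)c(OC)c2)c1` gives > 10000 nM, which is a limit of the assay. Compound 3 `COc1cc(-c2ncnn2-c2ccccc2)cc(OC)c1OC` gives > 10000 nM, again a limit. No pair among these three has a measured step, so compound 1 can be placed only as the single compound that returns a number.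

Compound 4 `COc1cc(-n2ncnc2-c2ccc(OC(C)C)cc2)cc(OC)c1OC` has isopropoxy in place of methyl on an aromatic carbon, para to a large group: isopropoxy in place of methyl on an aromatic carbon. Compound 2 also carries an ether side group and returns only the limit > 10000 nM, so a loss is expected rather than a gain. This is thin support, and the range stays wide. The expected change, a 4.8-fold higher number from compound 1 to compound 4 (0.68 log units; beyond the scatter), is a weakening beyond the usual scatter that stops short of the limit in this assay. For compound 4 the estimate is 1200 nM, with an expected range of 200 nM to 8000 nM.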

Compound 4, half-maximal inhibitory concentration: 600 nM
Beside the measured number, compound 4's estimate is 2.0-fold (0.30 log units) above it; low and high end bracket the measured number.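

In this assay, the step at the aromatic carbon para to a large group is a 2.4-fold higher number from compound 1 to compound 4 (0.38 log units; beyond the scatter). This first measured step in the series shows that the position tolerates isopropoxy in place of methyl with only a modest loss, so the larger ether-linked group does not abolish activity. Among these compounds, compound 4 returns a number and joins compound 1 as the only compounds clear of the assay limit: the limit of > 10000 nM in this assay, at which 2 of the 4 values shown sit.

With one replacement at this position, the compounds shown cannot separate the contribution of the ether oxygen from that of the branched chain. An ethyl chain or an amine at the same carbon would show whether the modest loss follows the chain or the oxygen.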